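Diethylamino in place of (1-methylheptyl)amino: compound 4

The source may report more compounds than this note shows. Statements on the series, on what has been measured and on what is new or still open speak of the compounds shown alone.

In an ADME assay on A549 cells (Homo sapiens) for cytotoxicity, read by resazurin assay, with a stated time of 48 h (on this read-out higher numbers stand for lower toxicity in this test and lower numbers for higher toxicity in this test), compound 1 `CCCCCCC(C)Nc1ccc(NC(=O)c2cc(Cl)ccc2O)c(Cl)c1` gives 23500 nM. Compound 2 `CCCCCCCCC(C)Nc1ccc(NC(=O)c2cc(Cl)ccc2O)c(Cl)c1` gives 21900 nM, and compound 3 `O=C(Nc1ccc(NCC2CCCC2)cc1Cl)c1cc(Cl)ccc1O` gives 21500 nM. Compound 1 therefore stands level with both of the others, all three values lying within the scatter of one another.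

The question now turns to compound 4 `CCN(CC)c1ccc(NC(=O)c2cc(Cl)ccc2O)c(Cl)c1`, which carries diethylamino in place of (1-methylheptyl)amino on an aromatic carbon. Within the data shown here, two measured steps bear on this change. Ethyl in place of hydrogen on a saturated chain carbon gives a 1.1-fold lower number from compound 1 to compound 2 (0.03 log units; within the scatter). Cyclopentylmethyl in place of 1-methylheptyl on a nitrogen on an aromatic ring gives a 1.1-fold lower number from compound 1 to compound 3 (0.04 log units; within the scatter). Both changes alter the same substituent, and neither moves the number beyond the scatter. Among the measured compounds shown here, none of the measured compounds carries diethylamino, however, so this particular group remains untested in this assay.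

On this evidence, no step beyond the scatter is expected in this assay, and no direction can be favoured. The estimated step is a 1.1-fold higher number from compound 1 to compound 4 (0.03 log units; within the scatter). For compound 4 the expected value is 25000 nM, with an estimated range of 12000 nM to 50000 nM.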

Compound 4, half-maximal cytotoxic concentration: 55500 nM
For compound 4 the middle estimate is 2.2-fold (0.35 log units) below the measured one; measured number outside the range, above it.
By their numbers in this assay, from the lowest: compounds 3, 2 and 1 (each within the scatter of the next); then compound 4.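

The earlier changes to this substituent had left the number in this assay within the scatter, whereas diethylamino on this aromatic carbon moves it beyond the scatter, with a 2.4-fold higher number from compound 1 to compound 4 (0.37 log units; beyond the scatter) and a 2.6-fold higher number from compound 3 to compound 4 (0.41 log units; beyond the scatter), both modest steps towards lower toxicity in this test. The position is therefore not indifferent to its substituent, although the change alters two counted features at once: diethylamino has 5 heavy atoms and 0 hydrogen-bond donors, against 9 heavy atoms and 1 hydrogen-bond donor for (1-methylheptyl)amino. No measurement available here accounts for the higher number.

The compounds shown leave open whether the step follows the smaller group or the loss of the hydrogen on the nitrogen, since the two go together in compound 4. An ethylamino group would keep that hydrogen on a short chain, while a methyl(1-methylheptyl)amino group would remove it from a long one, and either could help separate the two features.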